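From a Carboxylic Acid to a Nitro Group

The source may report more compounds than this note shows. Statements on the series, on what has been measured and on what is new or still open speak of the compounds shown alone.

Of the compounds shown here, three have been measured in a functional assay on SK-OV-3 cells (Homo sapiens) for inhibition, read by CCK-8 assay, with a stated time of 70 h (on this read-out lower numbers stand for stronger inhibition and higher numbers for weaker inhibition), and two of them reach only the edge of what it can report. Compound 2 `O=C(O)c1cccc(COc2ccc(OCCOCCNC3CCCC3)cc2)c1` carries a 3-carboxyphenyl group on a saturated chain carbon bound to an oxygen on an aromatic ring. In this assay compound 2 gives > 100000 nM, which is a limit of the assay and not a number. Compound 1 `c1ccc(COc2ccc(OCCOCCOC3CCCC3)cc2)cc1` likewise gives > 100000 nM in this assay, again a limit. Among the measured compounds shown here, compound 3 `OCCOCCOCCOc1ccc(OCc2ccccc2)cc1` is the only one with a number, giving 59400 nM in this assay. For the measured compounds named here, the single step that can be sized, an at least 1.6-fold lower number from compound 1 to compound 3 (0.22 log units; that floor lies within the scatter), concerns a different place on the molecule and says nothing direct about the change now at hand; what the two limits share is the limit of > 100000 nM in this assay, at which 2 of the 3 values shown sit.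

Compound 4 `O=[N+]([O-])c1ccccc1COc1ccc(OCCOCCNC2CCCC2)cc1` differs from compound 2 by 2-nitrophenyl in place of 3-carboxyphenyl on a saturated chain carbon bound to an oxygen on an aromatic ring. Going by the values given here, no measured step bears on this exchange, so there is no basis to expect a step beyond the scatter in either direction. Compound 4 is therefore estimated at 100000 nM, within a range from 30000 nM to 300000 nM, which would mean an expected step of a number no higher from compound 2 to compound 4 (the limit leaves the size open), with a fair chance that only a limit is reported again.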

Compound 4, half-maximal inhibitory concentration: 5370 nM
Compound 4: the middle estimate sits 19-fold (1.27 log units) above what was measured; measured number below the stated range.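

The place on a saturated chain carbon bound to an oxygen on an aromatic ring clearly matters in this assay: with 2-nitrophenyl in place of 3-carboxyphenyl, the read-out shows an at least 18-fold lower number from compound 2 to compound 4 (1.27 log units; beyond the scatter). The only step that could be sized among the earlier compounds concerned a different place and stayed within the scatter, so this is the first single change shown to move the number beyond it. The size of this step is only a floor because compound 2 gives a limit of the assay and not a number: the limit of > 100000 nM in this assay, at which 2 of the 4 values shown sit.

The exchange replaces the carboxylic acid with a nitro group and also changes where the substituent stands on the ring, so the compounds shown cannot tell which of these two differences accounts for the step. They also leave open whether an unsubstituted phenyl group, or a nitrile or an amine in place of the nitro group, would give a similarly low number on this shared core.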